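This account rests on a few compounds, and the source may have more. Where it says the series, first, only, none or still open, it means among the compounds named here.

Notes on the series in an ADME assay on S9 fraction from liver (Rattus norvegicus) for metabolic stability, with a stated time of 1 h; a higher number here means that more of the compound is left, a lower number that less of the compound is left: compound 3 `N#Cc1cnc(NCc2cnccc2C(F)(F)F)cc1NCCC1CCOCC1` stands lowest of the three measured compounds at 0%, against compound 2 `N#Cc1cnc(NCc2cnccc2C(F)(F)F)cc1NC1CCOCC1` at 17% and compound 1 `N#Cc1cnc(NCc2cnccc2C(F)(F)F)cc1NC[C@H]1C[C@@H](O)C1` at 44%. Compound 4 `N#Cc1cnc(NCc2cnccc2C(F)(F)F)cc1N[C@H]1CC[C@@H](C(N)=O)CC1` differs from compound 3 as follows: 4-carbamoylcyclohexyl in place of 2-(oxan-4-yl)ethyl on a nitrogen on an aromatic ring. The entering ring is of carbon only. Among the measured compounds shown here, no measured step makes this exchange. The nearest evidence is the changes on the same nitrogen: a number 27 percentage points lower from compound 1 to compound 2 (beyond the scatter), a number 17 percentage points lower from compound 2 to compound 3 (beyond the scatter) and a number 44 percentage points lower from compound 1 to compound 3 (beyond the scatter). These show that this substituent can shift the read-out by modest to large amounts. From the value of compound 3 at 0%, only an upward move is possible, so the expected change is a number 30 percentage points higher from compound 3 to compound 4 (beyond the scatter). For compound 4 the estimated value is 30%, with an expected range from 8% to 55%.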

Compound 4, percent of the compound remaining: 30%
The estimate for compound 4 equals the measured number at the digits printed, within the range that was stated.
By their numbers in this assay, from the lowest: compound 3; then compound 2; then compound 4; then compound 1.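

In this assay, this nitrogen tolerates a substituent with a ring of carbon only: 4-carbamoylcyclohexyl gives a number 30 percentage points higher from compound 3 to compound 4 (beyond the scatter) and a number 13 percentage points higher from compound 2 to compound 4 (beyond the scatter), so an oxane ring is not needed for a higher read-out. It does not match the hydroxylated substituent, with a number 14 percentage points lower from compound 1 to compound 4 (beyond the scatter). No measurement at hand bears on why the steps take these sizes. Going by these compounds, what stays open is the part played by the carbamoyl group itself, and what a plain cyclohexyl, a carboxylic acid or an amine on that ring would give.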